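Cyclohexyl for tert-butyl on the shared core

The source may report more compounds than this note shows. Statements on the series, on what has been measured and on what is new or still open speak of the compounds shown alone.

In a functional assay on U-251 cells (Homo sapiens) for inhibition, read by sulforhodamine B assay, with a stated time of 72 h (a lower number here means that less compound is needed, a higher number that more compound is needed for the effect), compound 1 `CC(C)(C)c1ccc(C(=O)/C=C/c2ccc([N+](=O)[O-])o2)cc1` gives 44500 nM, compound 2 `Cc1cccc(C(=O)/C=C/c2ccc([N+](=O)[O-])o2)c1` gives 2300 nM and compound 3 `CC(C)(C)c1ccc(C(=O)/C=C/c2ccco2)cc1` gives 16400 nM. Compound 3 therefore holds the second highest of the three numbers, with compound 1 higher and compound 2 lower.

The next step leads to compound 4 `O=C(/C=C/c1ccco1)c1ccc(C2CCCCC2)cc1`, not yet measured, which carries cyclohexyl in place of tert-butyl on an aromatic carbon.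

For the measured compounds named here, the only measured step is a 2.7-fold lower number from compound 1 to compound 3 (0.43 log units; beyond the scatter), with hydrogen in place of nitro on an aromatic carbon. That step is modest and lies elsewhere on the core. Going by the values given here, no measured step changes the tert-butyl group, so the data give no direction for this swap. No step beyond the scatter is expected in this assay. The estimated change is a 1.1-fold lower number from compound 3 to compound 4 (0.04 log units; within the scatter), which is expected to stay within the scatter. For compound 4 the estimated value is 15000 nM, with an expected range of 6000 nM to 38000 nM.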

Compound 4, half-maximal effective concentration: 26400 nM
Compound 4: middle estimate off by 1.8-fold (0.25 log units), on the low side, and the stated range covers the measured number.
By their numbers in this assay, from the lowest: compound 2; then compounds 3, 4 and 1 (each within the scatter of the next, the first and the last beyond it).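

Measured in this assay the swap of tert-butyl for cyclohexyl gives a 1.6-fold higher number from compound 3 to compound 4 (0.21 log units; within the scatter) and is the first change shown at this position on the aromatic carbon. Going from 4 heavy atoms without a ring to 6 heavy atoms in a six-membered non-aromatic ring therefore leaves the number within the scatter, so this pair gives no firm direction for the swap. No supporting data bear on this result.

Still open, on these data alone, is whether an amine or a carboxylic acid at this position would move the number beyond the scatter. The compounds shown also leave open whether the cyclohexyl swap would give a similar step on the core of compound 1, which carries nitro.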